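Dropping a Methyl From a Weak Growth Inhibitor

The source may hold more compounds than are shown below. What is called first, only, known or untested is meant among the compounds shown, and "the series" means these compounds.

Compound 1 `Cc1cc(C)c2c(O)cc(-c3ccc4ccccc4c3)nc2n1` gives 13200 nM in a functional assay on NCI-H460 cells (Homo sapiens) for antiproliferative activity (a lower number here means a stronger inhibitor of growth, a higher number a weaker inhibitor of growth), the highest number of the two measured here. Compound 2 `Cc1cnc2[nH]c(-c3cccc(Cl)c3)cc(=O)c2c1` gives 50.1 nM in this assay, a gap well beyond the usual scatter, so compound 1 is the weaker growth inhibitor of the pair. Compound 3 `Cc1ccnc2nc(-c3ccc4ccccc4c3)cc(O)c12` keeps the core of compound 1 and differs in one place: hydrogen in place of methyl on an aromatic carbon. Going by the values given here, no measured pair shows the effect of this change. The step of a 1.2-fold lower number from compound 1 to compound 3 (0.08 log units; within the scatter) is expected to be small, within the scatter. For compound 3 the estimate is 11000 nM, between 3500 nM and 35000 nM.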

Compound 3, concentration for 50% growth inhibition: 1050 nM
The estimate for compound 3 lay 10-fold (1.02 log units) above the measured number; measured number below the stated range.
By their numbers in this assay, from the lowest: compound 2; then compound 3; then compound 1.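

In this assay, hydrogen in place of methyl on this aromatic carbon, next to the ring nitrogen, gives a 13-fold lower number from compound 1 to compound 3 (1.10 log units; beyond the scatter). So at this position, the loss of a group of just 1 heavy atom is enough to shift growth inhibition clearly, and the methyl's absence goes with the stronger inhibitor. Nothing available explains why this step is so large. As far as these compounds go, whether an ethyl group, an amine or a methoxy group on this carbon would give a number nearer compound 1 or compound 3 remains open. Also open, from the compounds shown here alone, is what removing the remaining methyl of compound 3 would do.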